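Adding a second chloro to a flat series

This account rests on a few compounds, and the source may have more. Where it says the series, first, only, none or still open, it means among the compounds named here.

Measured in a functional assay on DU-145 cells (Homo sapiens) for inhibition, read by trypan blue exclusion, with a stated time of 96 h; on this read-out higher numbers stand for weaker inhibition of growth and lower numbers for stronger inhibition of growth:
- compound 1 `Cc1ccsc1/C=C(/SCc1ccc(Cl)cc1Cl)C(=O)c1ccc(Cl)cc1`: 10000 nM
- compound 2 `O=C(/C(=C/c1ccc(Cl)cc1)Cc1c[nH]c2ccccc12)c1ccc(Cl)cc1Cl`: 10000 nM
- compound 3 `O=C(/C(=C/c1ccc(Cl)cc1)Cc1ccc(Cl)cc1)c1ccc(Cl)cc1Cl`: 10000 nM

All three compounds stand level, so compound 3 at 10000 nM sits with the other two and has no measured neighbour on either side. Compound 4 `O=C(/C(=C/c1ccc(Cl)cc1)Cc1ccc(Cl)c(Cl)c1)c1ccc(Cl)cc1Cl` differs from it by one substitution: chloro in place of hydrogen on an aromatic carbon. This turns 4-chlorobenzyl into 3,4-dichlorobenzyl. Within the data shown here, one measured step touches this same side group, no change at the digits printed from compound 2 to compound 3 (within the scatter), and that exchange of a whole group left the value unmoved. Among the measured compounds shown here, no measured pair shows a chloro added to this ring, so this evidence is indirect. In this assay, no shift beyond the scatter is therefore expected, in either direction. The expected step is no change at the digits printed from compound 3 to compound 4 (within the scatter). Compound 4 is estimated at 10000 nM, with an expected range from 4000 nM to 20000 nM.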

Compound 4, concentration for 50% growth inhibition: 1000 nM
The estimate for compound 4 lay 10-fold (1.00 log units) above the measured number; the measured number lies below the stated range.
By their numbers in this assay, from the lowest: compound 4; then compounds 1, 2 and 3 (each within the scatter of the next).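

In this assay, the benzyl side group proves sensitive to a small change: one chloro in place of hydrogen, turning 4-chlorobenzyl into 3,4-dichlorobenzyl, gives a 10-fold lower number from compound 3 to compound 4 (1.00 log units; beyond the scatter). Exchanging 1H-indol-3-yl for 3,4-dichlorophenyl gives a 10-fold lower number from compound 2 to compound 4 (1.00 log units; beyond the scatter), whereas 4-chlorophenyl in that spot gave no change at the digits printed from compound 2 to compound 3 (within the scatter). Nothing measured here explains this gain in growth inhibition.

Going by these compounds, it remains open whether a fluoro, a methyl or a methoxy on the same ring carbon would also lower the number, or whether this gain depends on chloro itself.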